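Ethyl for Phenyl on a Urea Nitrogen of Compound 2

A few compounds are considered here, and "the series" means these few. Any claim that something is new, unique, unknown or untested is made for them only; others in the source may bear on it.

Of the compounds shown here, three that share a nucleoside-derived core have been measured in an ADME assay on HEL cells (Homo sapiens) for cytotoxicity, with a stated time of 3 days; on this read-out higher numbers stand for lower toxicity in this test and lower numbers for higher toxicity in this test. Compound 1 `Cc1cn([C@@H]2O[C@H](CO)[C@@]3(OS(=O)(=O)C=C3NC(=O)NC(=O)c3ccccc3)[C@H]2O)c(=O)n(C)c1=O` carries no silyl protection and a benzoyl urea; in this assay compound 1 reaches only the limit > 50000 nM, which is a limit and not a number. Compound 2 `Cc1cn([C@@H]2O[C@H](CO[Si](C)(C)C(C)(C)C)[C@@]3(OS(=O)(=O)C=C3NC(=O)Nc3ccccc3)[C@H]2O[Si](C)(C)C(C)(C)C)c(=O)n(C)c1=O` bears two silyl groups and a phenyl urea, and in this assay compound 2 gives 1300 nM, the lowest of the two numbers seen. Going by the values given here, compound 3 `Cc1cn([C@@H]2O[C@H](CO[Si](C)(C)C(C)(C)C)[C@@]3(OS(=O)(=O)C=C3NC(=O)N(C(=O)Nc3ccccc3)c3ccccc3)[C@H]2O[Si](C)(C)C(C)(C)C)c(=O)n(C)c1=O` adds a second phenylcarbamoyl group on the urea nitrogen, and in this assay compound 3 gives 13000 nM; the step of a 10-fold higher number from compound 2 to compound 3 (1.00 log units; beyond the scatter) is the only measured step, and it concerns an added group rather than an exchange.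

Compound 4 `CCNC(=O)NC1=CS(=O)(=O)O[C@@]12[C@@H](CO[Si](C)(C)C(C)(C)C)O[C@@H](n1cc(C)c(=O)n(C)c1=O)[C@@H]2O[Si](C)(C)C(C)(C)C` differs from compound 2 in one place: ethyl in place of phenyl on an amide-type nitrogen. Among the compounds with values here, no measured pair shows an exchange of phenyl for a small alkyl group on that nitrogen, so the one step on hand bears on it only loosely. A change of this kind is therefore expected to stay close to compound 2, with at most a small move towards a higher number. For compound 4 the estimate in this assay is 2000 nM, within 700 nM and 8000 nM. This amounts to an expected step of a 1.5-fold higher number from compound 2 to compound 4 (0.19 log units; within the scatter).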

Compound 4, half-maximal cytotoxic concentration: 10000 nM
For compound 4 the middle estimate is 5.0-fold (0.70 log units) below the measured one; measured number outside the range, above it.
By their numbers in this assay, from the lowest: compound 2; then compounds 4 and 3 (each within the scatter of the next). At a limit, above all of these: compound 1.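

The exchange of phenyl for ethyl on this amide-type nitrogen gives a 7.7-fold higher number from compound 2 to compound 4 (0.89 log units; beyond the scatter) in this assay, so the number in this test does depend on which group the nitrogen carries. Going by these compounds alone, until now the only measured change to compound 2 was an added group, with a 10-fold higher number from compound 2 to compound 3 (1.00 log units; beyond the scatter) on the urea, whereas this exchange removes the aromatic ring and puts a small chain in its place; both changes move to a higher number, and compound 2 remains the lowest of the compounds that have a number. Nothing measured here accounts for the size of this step.

On these data alone, whether a methyl group, a longer chain such as butyl, or a phenyl ring carrying an amine or a carboxylic acid would stay close to compound 2 or to compound 4 remains open. As far as these compounds go, the same exchange without the two silyl groups is also open, as compound 1 lacks them but also carries a benzoyl urea, and it gives > 50000 nM as a limit of the assay and not as a number.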